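The source may hold more compounds than are shown below. What is called first, only, known or untested is meant among the compounds shown, and "the series" means these compounds.

Two cores carry this short series. Compound 1 `COc1ccc(Cl)cc1C(=O)Nc1ccc(Cl)cc1O` and compound 3 `COc1ccc(Cl)cc1C(=S)Nc1cc(Cl)ccc1O` differ in more than one place, and the difference between the two cores is not broken down here. In a functional assay on HepG2 cells (Homo sapiens) for cytotoxicity, with a stated time of 24 h (a higher number here means a weaker inhibitor, a lower number a stronger inhibitor), compound 1 gives 51300 nM. Compound 2 `COc1ccc(Cl)cc1C(=O)Nc1cc(Cl)c(Cl)cc1O` carries, relative to compound 1, the change (chloro in place of hydrogen on an aromatic carbon), and in this assay compound 2 gives 2980 nM; the step is a 17-fold lower number from compound 1 to compound 2 (1.24 log units; beyond the scatter). In this assay compound 3 gives 8600 nM, the second highest of the three numbers, with its gaps to compound 2 and to compound 1 both beyond the scatter.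

Compound 4 `COc1ccc(Cl)cc1C(=S)Nc1cc(Cl)c(Cl)cc1O` has not been measured. Relative to compound 3 it carries the change (chloro in place of hydrogen on an aromatic carbon). This is the same kind of change as that from compound 1 to compound 2, not the same: in compound 2 the entering chloro is meta to a large group and para to a hydroxy group, whereas in compound 4 it is meta to a hydroxy group and para to a large group, and the cores differ as well. Within the data shown here, only one earlier instance of the change exists. The step from compound 3 to compound 4 is expected to be an 8.6-fold lower number from compound 3 to compound 4 (0.93 log units; beyond the scatter), a lowering that rests on a 17-fold lower number from compound 1 to compound 2 (1.24 log units; beyond the scatter) but is taken as smaller because the surroundings of the place differ and a 17-fold lower number from compound 1 to compound 2 (1.24 log units; beyond the scatter) is a single observation. Compound 4 is accordingly expected to give about 1000 nM, with the range 300 nM to 4000 nM.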

Compound 4, half-maximal inhibitory concentration: 3720 nM
For compound 4 the middle estimate is 3.7-fold (0.57 log units) below the measured one, and the stated range covers the measured number.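

In this assay the chloro in place of hydrogen on an aromatic carbon gives a 2.3-fold lower number from compound 3 to compound 4 (0.36 log units; beyond the scatter) on the core of compound 3, so the number falls on both cores, but the size of the step does not carry over: the same change on two cores in this assay, a 17-fold lower number (1.24 log units; beyond the scatter) from compound 1 to compound 2 and a 2.3-fold lower number (0.36 log units; beyond the scatter) from compound 3 to compound 4, 7.4-fold (0.87 log units) apart, beyond the scatter of two such steps.

These two instances show that the change lowered the number on each of the two cores; they do not show that it would do so on a further core, and the size found on one core proved a poor guide to the size on the other. The two instances differ both in the core and in where the entering chloro stands relative to the hydroxy group and the large group, and the data cannot separate these two differences as the source of the gap.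

Still open, going by these compounds, is whether a group other than chloro at this place, such as bromo, methyl or a nitrile, would move the number in the same direction on both cores. Also open, on these data alone, is whether the gap between the two steps would persist with an amine or a carboxylic acid in place of the hydroxy group.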